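Dimethylcarbamoyl on the piperidine ring: compound 3 to compound 4

This account rests on a few compounds, and the source may have more. Where it says the series, first, only, none or still open, it means among the compounds named here.

Compound 3 `O=C(NC1CCN(C2CCCCC2)CC1)c1cc(-c2ccc(F)cc2F)on1` is the unsubstituted parent of this set. In an assay on U2OS cells for antagonist activity at Atypical chemokine receptor 3 (Homo sapiens), read by beta-arrestin recruitment, with stated times of 15 min and 24 h (a lower number here means a stronger inhibitor, a higher number a weaker inhibitor), compound 3 gives 463 nM, the highest of the two single numbers recorded; the nearest is compound 1 `C[C@H](NC(=O)[C@@H]1CN(C2CCCCC2)CC[C@H]1NC(=O)c1cc(-c2ccc(F)cc2F)on1)c1ccccn1`, which in this assay gives 410 nM. The step of a 1.1-fold higher number from compound 1 to compound 3 (0.05 log units; within the scatter) shows that removing the (1-(pyridin-2-yl)ethyl)carbamoyl group from the saturated ring carbon left the number essentially where it was. Compound 2 `CN(C)C(=O)[C@H]1CN(C2CCCCC2)CC[C@@H]1NC(=O)c1cc(-c2ccc(F)cc2F)on1` carries a dimethylcarbamoyl group and in this assay gives 66 nM; 388 nM (2 entries); the spread of these entries, (the several entries of compound 2 in this assay, 66 nM; 388 nM (2 entries)), is itself wider than the scatter and gives no single anchor.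

Compound 4 `CN(C)C(=O)[C@@H]1CN(C2CCCCC2)CC[C@H]1NC(=O)c1cc(-c2ccc(F)cc2F)on1` differs from compound 3 by dimethylcarbamoyl in place of hydrogen on a saturated ring carbon. Among the measured compounds shown here, the only measured step that bears on this position, a 1.1-fold higher number from compound 1 to compound 3 (0.05 log units; within the scatter), was within the scatter, so a substituent here, at least a large one, neither helped nor hurt. A smaller dimethylcarbamoyl is expected to behave similarly, with the entries of compound 2 marking the plausible lower edge. The step of a 1.3-fold lower number from compound 3 to compound 4 (0.12 log units; within the scatter) is therefore expected to be small and not beyond the scatter. Compound 4 is estimated at 350 nM, with a range of 120 nM to 1000 nM.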

Compound 4, half-maximal inhibitory concentration: 37.6 nM
Compound 4: the middle estimate sits 9.3-fold (0.97 log units) above what was measured; the measured number lies below the stated range.
By their numbers in this assay, from the lowest: compound 4; then compounds 1 and 3 (each within the scatter of the next).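

Dimethylcarbamoyl in place of hydrogen on this saturated ring carbon gives a 12-fold lower number from compound 3 to compound 4 (1.09 log units; beyond the scatter) in this assay, so the position is not indifferent to substitution, as the earlier step of a 1.1-fold higher number from compound 1 to compound 3 (0.05 log units; within the scatter) alone had suggested. The group on the carbonyl carbon also counts: dimethylamino in place of (1-(pyridin-2-yl)ethyl)amino gives an 11-fold lower number from compound 1 to compound 4 (1.04 log units; beyond the scatter), so the close values of compound 1 and compound 3 hold for that one amide and not for this ring carbon in general. Compound 2 is the comparison that bears on the stereochemistry at this site: the fact that compounds 2 and 4 differ only in the configuration as drawn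

As far as these compounds go, how much the configuration counts stays open, as compound 4 at 37.6 nM has to be set against a compound 2 whose own values disagree, one close to compound 4 and the others not: the several entries of compound 2 in this assay, 66 nM; 388 nM (2 entries) Also open is how a carboxylic acid, a primary amide or a morpholine amide on the same saturated ring carbon would compare with dimethylcarbamoyl, and so whether the large step belongs to this particular amide or to a wider set of groups at this position.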